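This account rests on a few compounds, and the source may have more. Where it says the series, first, only, none or still open, it means among the compounds named here.

Going by the values given here, in a functional assay on K562 cells (Homo sapiens), read by MTT assay, with a stated time of 72 h (on this read-out higher numbers stand for weaker inhibition and lower numbers for stronger inhibition), compound 1 (`CSc1ncnc2c1c(-c1ccoc1)cn2[C@@H]1O[C@H](CO)[C@@H](O)[C@H]1O`) gives 60 nM, the only true number so far. Compound 2 (`CSc1ncnc2c1c(-c1ccccc1)cn2[C@@H]1O[C@H](CO)[C@@H](O)[C@H]1O`), with phenyl in place of furan-3-yl, reads > 20000 nM, which is a limit of the assay. Among the compounds with values here, that swap, an at least 330-fold higher number from compound 1 to compound 2 (2.52 log units; beyond the scatter), is large but lies at a different place, so it shows only that one change can matter greatly. Compound 3 (`CN(C)c1ncnc2c1c(-c1ccoc1)cn2[C@@H]1O[C@H](CO)[C@@H](O)[C@H]1O`) keeps the furan-3-yl group and carries dimethylamino in place of methylsulfanyl on an aromatic carbon. Within the data shown here, no measured step covers this change, so only a moderate rise, with wide uncertainty, is expected: a 17-fold higher number from compound 1 to compound 3 (1.22 log units; beyond the scatter). For compound 3 the estimated value is 1000 nM, with a range of 100 nM to 20000 nM.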

Compound 3, half-maximal inhibitory concentration: 1540 nM
Estimate against measurement, compound 3: 1.5-fold (0.19 log units) below; measured number inside the range.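

The carbon next to the ring nitrogen is therefore sensitive too, not only the place that carries furan-3-yl: in this assay, dimethylamino in place of methylsulfanyl gives a 26-fold higher number from compound 1 to compound 3 (1.41 log units; beyond the scatter). The two groups match in hydrogen-bond donors, hydrogen-bond acceptors and net charge, so those counts do not separate them. No measurement here explains the size of this step. Open, going by these compounds, is whether a plain amino group or methylamino at this place would stay closer to compound 1, and how a longer chain on the sulfur would read.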